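From a Cyclopentenyl Ring to an Open Fluorinated Chain

The source may report more compounds than this note shows. Statements on the series, on what has been measured and on what is new or still open speak of the compounds shown alone.

Three compounds sharing one core differ only in a single group on an aromatic carbon. In an in vitro ADME assay on microsomes from liver (Homo sapiens) for metabolic stability, tested at 5 uM (on this read-out lower numbers stand for a shorter-lived compound and higher numbers for a longer-lived compound), compound 1 `CC(C)CCn1nc(C2CCCCC2)c(O)c(C2=NS(=O)(=O)c3cc(NS(C)(=O)=O)ccc3N2)c1=O` gives 0.117 h, compound 2 `CC(C)CCn1nc(C2CCC2)c(O)c(C2=NS(=O)(=O)c3cc(NS(C)(=O)=O)ccc3N2)c1=O` gives 0.317 h, and compound 3 `CC(C)CCn1nc(C2=CCCC2)c(O)c(C2=NS(=O)(=O)c3cc(NS(C)(=O)=O)ccc3N2)c1=O` gives 0.933 h, the highest of the three numbers.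

Compound 4 `CC(C)CCn1nc(CCC(F)(F)F)c(O)c(C2=NS(=O)(=O)c3cc(NS(C)(=O)=O)ccc3N2)c1=O` has not yet been measured. It carries 3,3,3-trifluoropropyl in place of the cyclopent-1-en-1-yl of compound 3 (3,3,3-trifluoropropyl in place of cyclopent-1-en-1-yl on an aromatic carbon).

All three measured steps change the group at this same place. They are a 2.7-fold higher number from compound 1 to compound 2 (0.43 log units; beyond the scatter), a 2.9-fold higher number from compound 2 to compound 3 (0.47 log units; beyond the scatter) and an 8.0-fold higher number from compound 1 to compound 3 (0.90 log units; beyond the scatter), each modest but beyond the scatter. They show that this assay responds to changes here, but none of these compounds has an open chain or fluorine, so they offer only weak guidance on direction. The expected change is small and slightly upward, with no step beyond the scatter, namely a 1.3-fold higher number from compound 3 to compound 4 (0.11 log units; within the scatter). The estimate for compound 4 is 1.2 h, with an expected range from 0.4 h to 3.2 h.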

Compound 4, half-life: 0.517 h
The estimate for compound 4 lay 2.3-fold (0.37 log units) above the measured number; low and high end bracket the measured number.
By their numbers in this assay, from the lowest: compound 1; then compounds 2, 4 and 3 (each within the scatter of the next, the first and the last beyond it).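

In this assay an open chain at this position reads much like the two small rings, so a ring on this aromatic carbon is not needed to keep the number in this range: a 1.8-fold lower number from compound 3 to compound 4 (0.26 log units; within the scatter) and a 1.6-fold higher number from compound 2 to compound 4 (0.21 log units; within the scatter) both lie within the scatter, and compound 4 cannot be told apart from compound 3 or compound 2. Among the compounds shown here, only the cyclohexyl of compound 1 stands apart from the 3,3,3-trifluoropropyl chain, with a 4.4-fold higher number from compound 1 to compound 4 (0.65 log units; beyond the scatter) as the one new step beyond the scatter. Nothing measured here accounts for these results.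

The compounds shown leave open whether a plain propyl chain, without the fluorine, would read like compound 4. They also leave open how a longer fluorinated chain or an amine at this same place would read.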